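A few compounds are considered here, and "the series" means these few. Any claim that something is new, unique, unknown or untested is made for them only; others in the source may bear on it.

Measured so far in a functional assay on MV4-11 cells (Homo sapiens) for inhibition, read by luminescence and CellTiter-Glo, with a stated time of 72 h; a lower number here means a stronger inhibitor of growth, a higher number a weaker inhibitor of growth:
compound 1 `C[C@H]1CN(C(=O)c2ccco2)c2cc(-c3ccc(S(C)(=O)=O)cc3)ccc2N1C(=O)C1CC1`: 280 nM
compound 2 `CC(=O)N1c2ccc(-c3ccc(S(C)(=O)=O)cc3)cc2N(C(=O)c2ccco2)C[C@@H]1C`: 400 nM
compound 3 `CC(=O)N1c2ccc(-c3ccc(S(C)(=O)=O)cc3)cc2N(C(=O)OC(C)C)C[C@@H]1C`: 350 nM

Compound 2 gives the highest of the three numbers in this assay, but its gaps to the others are small, a 1.4-fold higher number from compound 1 to compound 2 (0.15 log units; within the scatter) and a 1.1-fold lower number from compound 2 to compound 3 (0.06 log units; within the scatter), both within the scatter, so the three stand level. Compound 4 `CC(=O)N1c2ccc(-c3ccccc3)cc2N(C(=O)c2ccco2)C[C@@H]1C` takes a different kind of step from compound 2: hydrogen in place of methylsulfonyl on an aromatic carbon. Neither measured step touches this position; both exchanged one carbonyl substituent on the shared core for another and stayed within the scatter. Nothing measured therefore bears on this change, which removes a substituent outright rather than swapping it. For compound 4 a weaker number is expected, a 2.5-fold higher number from compound 2 to compound 4 (0.40 log units; beyond the scatter), with wide uncertainty. Compound 4 is estimated at 1000 nM, range 250 nM to 4000 nM.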

Compound 4, concentration for 50% growth inhibition: 350 nM
Compound 4: the middle estimate sits 2.9-fold (0.46 log units) above what was measured, and the stated range covers the measured number.
By their numbers in this assay, from the lowest: compounds 1, 3, 4 and 2 (each within the scatter of the next).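

Removing methylsulfonyl gives a 1.1-fold lower number from compound 2 to compound 4 (0.06 log units; within the scatter) in this assay. Going by these compounds alone, this is the first change away from the carbonyl substituents, and it shows that the number at this place on the aromatic ring does not depend on methylsulfonyl, at least in this one pair. Nothing available gives a reason for this result.

Within the data shown here, whether the same holds with cyclopropyl or isopropoxy on the carbonyl carbon remains open, since only this pair speaks for the position. Also open, going by these compounds, is how an amine or a carboxylic acid would read at this place.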